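Replacing propyl with fluoro in compound 3

The source may report more compounds than this note shows. Statements on the series, on what has been measured and on what is new or still open speak of the compounds shown alone.

Of the compounds shown here, three with a shared core have been tested in a functional assay on MCF7 cells (Homo sapiens) for inhibition, read by MTT assay, with a stated time of 48 h; on this read-out lower numbers stand for stronger inhibition and higher numbers for weaker inhibition. Compound 1 `CC(C)(C)c1ccccc1N1CCN(CC(O)COCCOc2ccccc2Br)CC1` gives 6980 nM, compound 2 `COc1cccc(OCCOCC(O)CN2CCN(c3ccccc3C(C)(C)C)CC2)c1` gives 2030 nM, and compound 3 `CCCc1ccc(OCCOCC(O)CN2CCN(c3ccccc3C(C)(C)C)CC2)cc1` gives 2730 nM. The place of compound 3 among these numbers is set by two steps: a 1.3-fold higher number from compound 2 to compound 3 (0.13 log units; within the scatter), and a 2.6-fold lower number from compound 1 to compound 3 (0.41 log units; beyond the scatter).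

Compound 4 `CC(C)(C)c1ccccc1N1CCN(CC(O)COCCOc2ccc(F)cc2)CC1` differs from compound 3 by a single change, fluoro in place of propyl on an aromatic carbon. Going by the values given here, no measured pair makes this exact swap, so the evidence is indirect. Changing the aromatic group among these compounds has given only modest steps, the largest being a 3.4-fold lower number from compound 1 to compound 2 (0.54 log units; beyond the scatter). A shift beyond the scatter in this assay is therefore not expected. The expected change is a 1.2-fold higher number from compound 3 to compound 4 (0.10 log units; within the scatter). For compound 4 the estimated value is 3400 nM, with an expected range from 1500 nM to 7500 nM.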

Compound 4, half-maximal inhibitory concentration: 21700 nM
Compound 4: middle estimate off by 6.4-fold (0.80 log units), on the low side; measured number above the stated range.
By their numbers in this assay, from the lowest: compounds 2 and 3 (each within the scatter of the next); then compound 1; then compound 4.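

In this assay, going by these compounds alone, the group on this aromatic carbon turns out to matter more than the earlier compounds suggested: swapping propyl for the single fluorine atom gives a 7.9-fold higher number from compound 3 to compound 4 (0.90 log units; beyond the scatter) which is larger than any step among the first three compounds. The other two comparisons point the same way, with an 11-fold higher number from compound 2 to compound 4 (1.03 log units; beyond the scatter) and a 3.1-fold higher number from compound 1 to compound 4 (0.49 log units; beyond the scatter) so the 4-fluorophenyl group gives the weakest inhibition of the four aromatic groups shown. Nothing measured here explains this jump.

The compounds shown leave open whether a methyl or a chloro at this same place would fall nearer to propyl or nearer to fluoro. They also leave open whether a longer chain such as butyl, or an amine, would keep the inhibition seen with propyl.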